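A few compounds are considered here, and "the series" means these few. Any claim that something is new, unique, unknown or untested is made for them only; others in the source may bear on it.

Compound 1, `Oc1cccc(-c2cc(-c3cccc(Cl)c3)nc(-c3ccco3)c2)c1`, was tested in an assay on isolated protein for inhibition of DNA topoisomerase 1 (Homo sapiens), with a stated time of 30 min, tested at 100 uM (on this read-out lower numbers stand for a weaker effect and higher numbers for a stronger effect at the one concentration tested), where compound 1 gives 5.5%. That is the lowest of the three numbers measured: compound 2, `Oc1cccc(-c2cc(-c3ccc(Cl)cc3)nc(-c3ccco3)c2)c1`, gives 27.1%, and compound 3, `Oc1ccc(-c2cc(-c3cccc(Cl)c3)nc(-c3ccco3)c2)cc1`, gives 25.5%. The two measured steps are a number 21.6 percentage points higher from compound 1 to compound 2 (beyond the scatter) and a number 20 percentage points higher from compound 1 to compound 3 (beyond the scatter), and each swaps a chlorophenyl or hydroxyphenyl group for its isomer, leaving the furan-2-yl group untouched. The unmeasured compound 4, `Oc1cccc(-c2cc(-c3ccccc3)nc(-c3cccc(Cl)c3)c2)c1`, differs from compound 1 by phenyl in place of furan-2-yl on an aromatic carbon. For the measured compounds named here, no measured step touches that part of the shared core, so the two modest rises point to no direction here. Compound 4 is therefore expected to stay near compound 1, the expected step being a number 6.5 percentage points higher from compound 1 to compound 4 (within the scatter). The estimate for compound 4 is 12%, within 0% to 35%.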

Compound 4, a percentage reported as inhibition, at one concentration (the size of the read-out at that concentration, not a potency): 11.5%
For compound 4 the middle estimate is 0.5 percentage points above the measured one; measured number inside the range.
By their numbers in this assay, from the lowest: compounds 1 and 4 (each within the scatter of the next); then compounds 3 and 2 (each within the scatter of the next).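

Putting phenyl in place of furan-2-yl, next to the ring nitrogen, gives a number 6 percentage points higher from compound 1 to compound 4 (within the scatter). So on this scaffold, a six-membered carbon ring can stand in for the five-membered ring and its hydrogen-bond acceptor without a change that rises above the scatter. No measurement here offers an explanation for this outcome.

Both compounds in this step give low numbers, so the same swap might behave differently on compound 2 or compound 3. On these data alone, how an amine or a carboxylic acid on the phenyl ring would fare at this position also remains open.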